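This account rests on a few compounds, and the source may have more. Where it says the series, first, only, none or still open, it means among the compounds named here.

Compounds measured so far in a functional assay on MDA-MB-231 cells (Homo sapiens) for cytotoxicity, read by MTT assay, with a stated time of 72 h (a higher number here means a weaker inhibitor, a lower number a stronger inhibitor), are:

Compound 1 `O=C(CN1CCN(c2nnc(Cc3ccncc3)c3ccccc23)CC1)Nc1cccc(Br)c1` gives 1.7 nM here
Compound 2 `O=C(CN1CCN(c2nnc(Cc3ccncc3)c3ccccc23)CC1)Nc1ccc(Br)cc1` gives 19 nM here
Compound 3 `O=C(CN1CCN(c2nnc(Cc3ccccc3)c3ccccc23)CC1)Nc1cc(C(F)(F)F)ccc1Cl` gives 19500 nM here

Compound 3, at 19500 nM, has the highest of the three numbers and so sits well apart from the other two. Compound 4 `O=C(CN1CCN(c2nnc(Cc3ccncc3)c3ccccc23)CC1)Nc1cc(C(F)(F)F)ccc1Cl` differs from compound 3 in one group (pyridin-4-yl in place of phenyl on a saturated chain carbon bound to an aromatic carbon), with pyridin-4-yl in place of phenyl on a saturated chain carbon bound to an aromatic carbon.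

For the measured compounds named here, no measured step isolates this change. Going by the values given here, the only step available, an 11-fold higher number from compound 1 to compound 2 (1.05 log units; beyond the scatter), concerns the bromophenyl group on an amide-type nitrogen, but it does show that one change can move the number beyond the scatter in these compounds. The closest evidence is indirect. Compound 1 (1.7 nM) and compound 2 (19 nM) both carry pyridin-4-yl and give far lower numbers than compound 3, yet their aryl group on the amide-type nitrogen also differs from that of compound 3, and compound 4 keeps the aryl group of compound 3. A large step towards a lower number is therefore expected in this assay, though only part of that gap may carry over. The expected size of the change is a 65-fold lower number from compound 3 to compound 4 (1.81 log units; beyond the scatter) by this estimate. Compound 4 is expected at 300 nM with an estimated range from 8 nM to 9000 nM for now.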

Compound 4, half-maximal inhibitory concentration: 3.7 nM
Compound 4: middle estimate off by 81-fold (1.91 log units), on the high side, outside the stated range (below it).
By their numbers in this assay, from the lowest: compound 1; then compound 4; then compound 2; then compound 3.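

For the compounds shown here, with the rest of the molecule unchanged, pyridin-4-yl in place of phenyl on a saturated chain carbon bound to an aromatic carbon gives a 5300-fold lower number from compound 3 to compound 4 (3.72 log units; beyond the scatter) in this assay and provides the first direct reading of this change. With pyridin-4-yl in place, the group on the amide-type nitrogen has a much smaller effect: 2-chloro-5-(trifluoromethyl)phenyl in place of 4-bromophenyl gives a 5.1-fold lower number from compound 2 to compound 4 (0.71 log units; beyond the scatter) and in place of 3-bromophenyl gives a 2.2-fold higher number from compound 1 to compound 4 (0.34 log units; beyond the scatter), two modest steps that still lie beyond the scatter. Going by these compounds alone, nothing available explains why this single exchange moves the number so far.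

The compounds shown do not reveal whether the effect is specific to pyridin-4-yl, since they include neither pyridin-3-yl, pyridin-2-yl nor pyrimidinyl on that carbon, and they include no longer chain in place of the saturated chain carbon. They also leave open whether phenyl in place of pyridin-4-yl would cost as much in compounds carrying 3-bromophenyl or 4-bromophenyl on the amide-type nitrogen.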